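The source may report more compounds than this note shows. Statements on the series, on what has been measured and on what is new or still open speak of the compounds shown alone.

Of the compounds shown here, three built on one shared core have been measured in an ADME assay for permeability, using PAMPA, at pH 4; on this read-out lower numbers stand for lower permeability and higher numbers for higher permeability. Compound 1 `CCCCCCCc1c(C)[nH]c2cc(OC)c(Cl)cc2c1=O`, which carries a heptyl group on an aromatic carbon of the core, gives only a limit of the assay, < 0.01 10^-6 cm/s. Compound 2 `COc1cc2[nH]c(C)c(C(C)C)c(=O)c2cc1Cl`, with isopropyl in the same place, gives 281 10^-6 cm/s. Compound 3 `COc1cc2[nH]c(C)c(Br)c(=O)c2cc1Cl`, with bromo there, gives 125 10^-6 cm/s. Of the two numbers actually measured, compound 3 stands lowest, with compound 2 nearest at a 2.2-fold lower number from compound 2 to compound 3 (0.35 log units; beyond the scatter); the third value is not a number but (the limit of < 0.01 10^-6 cm/s in this assay, at which 1 of the 3 values shown sits).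

Compound 4 `CCCCC/C=C/c1c(C)[nH]c2cc(OC)c(Cl)cc2c1=O` is the next compound in line: hept-1-en-1-yl in place of bromo on an aromatic carbon. Among the measured compounds shown here, two measured steps bear on this change. The step of an at least 12000-fold higher number from compound 1 to compound 3 (4.09 log units; beyond the scatter) and the step of an at least 28000-fold higher number from compound 1 to compound 2 (4.44 log units; beyond the scatter) both show that swapping heptyl for a small group lifts the number enormously. Compound 4 runs that exchange in reverse, putting hept-1-en-1-yl where bromo stood, a group that differs from heptyl only by one double bond outside the aromatic rings. A large drop from compound 3 is therefore expected, and the estimated step is a 2500-fold lower number from compound 3 to compound 4 (3.40 log units; beyond the scatter). Compound 4 is expected at 0.05 10^-6 cm/s, with a range from 0.005 10^-6 cm/s to 3 10^-6 cm/s, and there is a real chance that this assay once more reports only a limit.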

Compound 4, apparent permeability: 280 10^-6 cm/s
Beside the measured number, compound 4's estimate is 5600-fold (3.75 log units) below it, and the stated range ends below it.
By their numbers in this assay, from the lowest: compound 3; then compounds 4 and 2 (each within the scatter of the next). At a limit, below all of these: compound 1.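

In this assay a long chain at this position does not by itself go with a low number: hept-1-en-1-yl in place of bromo gives a 2.2-fold higher number from compound 3 to compound 4 (0.35 log units; beyond the scatter), and hept-1-en-1-yl in place of isopropyl gives a 1.0-fold lower number from compound 2 to compound 4 (0.00 log units; within the scatter), which leaves those two compounds level within the scatter. Compound 1, with heptyl, goes against any simple rule based on chain size, and the change that matters most among these compounds is a small one on paper, since hept-1-en-1-yl in place of heptyl, a difference of one double bond outside the aromatic rings, gives an at least 28000-fold higher number from compound 1 to compound 4 (4.44 log units; beyond the scatter). The value of compound 1 is a limit and not a number: the limit of < 0.01 10^-6 cm/s in this assay, at which 1 of the 4 values shown sits.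

The compounds shown leave open whether the double bond or the chain length decides the outcome, for instance whether a shorter pentenyl chain or a longer nonenyl chain at this place would read like hept-1-en-1-yl or like heptyl. They also leave open how a chain ending in an amine or a carboxylic acid would read in this assay at this position.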